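Swapping Chloro for Trifluoromethyl on Compound 2

The source may hold more compounds than are shown below. What is called first, only, known or untested is meant among the compounds shown, and "the series" means these compounds.

In a functional assay on NCI-H1975 cells (Homo sapiens) for inhibition, read by MTT assay, with a stated time of 72 h (on this read-out lower numbers stand for stronger inhibition and higher numbers for weaker inhibition), compound 1 `C=CC(=O)Nc1cccc(NC(=O)CSc2nc(Nc3cccc([N+](=O)[O-])c3)c3ccccc3n2)c1` gives 22600 nM, and compound 2 `C=CC(=O)Nc1cccc(NC(=O)CSc2nc(Nc3ccc(Cl)cc3)c3ccccc3n2)c1` gives 7580 nM, the lowest of the two numbers. Going by the values given here, the single measured step, a 3.0-fold lower number from compound 1 to compound 2 (0.47 log units; beyond the scatter), shows that changing the group on this aromatic ring can move the number beyond the scatter. Compound 3 `C=CC(=O)Nc1cccc(NC(=O)CSc2nc(Nc3ccc(C(F)(F)F)cc3)c3ccccc3n2)c1` differs from compound 2 by trifluoromethyl in place of chloro on an aromatic carbon. Among the compounds with values here, no measured step covers this exact swap, so only a small change is expected, a 1.1-fold lower number from compound 2 to compound 3 (0.03 log units; within the scatter) in this assay. Compound 3 is therefore estimated at 7000 nM, within a range from 2500 nM to 20000 nM.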

Compound 3, half-maximal inhibitory concentration: 12900 nM
For compound 3 the middle estimate is 1.8-fold (0.27 log units) below the measured one; the range from low to high includes it.
By their numbers in this assay, from the lowest: compounds 2, 3 and 1 (each within the scatter of the next, the first and the last beyond it).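

In this assay, the larger trifluoromethyl, with four heavy atoms against one, does not clearly separate from chloro at this place on the ring: the swap gives a 1.7-fold higher number from compound 2 to compound 3 (0.23 log units; within the scatter) and stays within the scatter. Replacing 3-nitrophenyl gives a 1.8-fold lower number from compound 1 to compound 3 (0.24 log units; within the scatter) and is also within the scatter, so compound 3 cannot be told apart from either neighbour, although compound 1 and compound 2 remain apart. No measured evidence is available to explain these results. The compounds shown leave open how an amine or a carboxylic acid in place of chloro would read here.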